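Cytotoxicity of a cyclopentylsulfanyl analogue of compound 2

The compounds below may be only part of what the source reports. "The series", "measured", "known", "first", "only" and "open" are said of these compounds alone.

Compound 1 `Nc1nc2c(ncn2/C=C2/CC2(CO)CO)c(=O)[nH]1`: in an ADME assay on Akata cells (Homo sapiens) for cytotoxicity, with a stated time of 7 days (on this read-out lower numbers stand for higher toxicity in this test and higher numbers for lower toxicity in this test), compound 1 gives > 20000 nM, a limit of the assay.
Compound 2 `Nc1nc(N2CCCC2)c2ncn(/C=C3/CC3(CO)CO)c2n1`: in this assay compound 2 gives > 24000 nM, a limit of the assay.
Compound 3 `CCCCCOc1nc(N)nc2c1ncn2/C=C1/CC1(CO)CO`: in this assay compound 3 gives > 20000 nM, a limit of the assay.

Compound 2 stands among three compounds of which none gives a number in this assay: its own value is a limit, and the two further values shown are limits as well. Two of the three values sit at the limit of > 20000 nM in this assay, at which 2 of the 3 values shown sit, and one at the limit of > 24000 nM in this assay, at which 1 of the 3 values shown sits. Within the data shown here, the only step measured between compounds that differ in one place, a step that the two limits leave unreadable from compound 2 to compound 3, cannot be read because both of its ends are limits, so its size is unknown.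

Compound 4 `Nc1nc(SC2CCCC2)c2ncn(/C=C3/CC3(CO)CO)c2n1` differs from compound 2 by cyclopentylsulfanyl in place of pyrrolidin-1-yl on an aromatic carbon. Among the measured compounds shown here, no measured step with a readable size bears on this change, and no measured step in this assay shows anything beyond the scatter. For the measured compounds named here, compound 4 is therefore expected to behave like compound 2, giving a value that most likely is again a limit, because every value so far sits at the limit of > 20000 nM in this assay, at which 2 of the 3 values shown sit, or at the limit of > 24000 nM in this assay, at which 1 of the 3 values shown sits. The estimate for compound 4 in this assay is 30000 nM, within a range from 10000 nM to 100000 nM. The step expected from that estimate is a step that the limit leaves unreadable from compound 2 to compound 4, which is not expected to exceed the scatter.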

Compound 4, half-maximal cytotoxic concentration: > 20000 nM
Compound 4: only a limit was reported (the forecaster's own chance of this, stated with the estimate: 80%); the middle value is on the limit's open side.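

In this assay compound 4 gives > 20000 nM, a limit of the assay. The steps from compound 2 to compound 4 and from compound 3 to compound 4 therefore cannot be read, as both ends of each are limits. The compounds shown leave open whether pyrrolidin-1-yl, pentyloxy and cyclopentylsulfanyl differ at all in this test, and at what concentration any of these compounds would reach the half-maximal cytotoxic level.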